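The source may report more compounds than this note shows. Statements on the series, on what has been measured and on what is new or still open speak of the compounds shown alone.

Measured compounds:
- compound 1, `COc1ccc(-c2nnc(SCCn3c([N+](=O)[O-])cnc3C)o2)cc1`, 10600 nM
- compound 2, `CCOc1ccc(-c2nnc(SCCn3c([N+](=O)[O-])cnc3C)o2)cc1`, 16600 nM
- compound 3, `Cc1ncc([N+](=O)[O-])n1CCSc1nnc(-c2ccc(N(C)C)cc2)o1`, 14900 nM

All three values come from a functional assay on MCF7 cells (Homo sapiens) for cytotoxicity, read by MTT assay, with a stated time of 48 h; a higher number here means a weaker inhibitor, a lower number a stronger inhibitor. Compound 1 stands lowest of the three, but its lead is small: its nearest neighbour is compound 3, and the step of a 1.4-fold higher number from compound 1 to compound 3 (0.15 log units; within the scatter) is within the scatter, as is the step of a 1.6-fold higher number from compound 1 to compound 2 (0.19 log units; within the scatter) to the furthest of the three. Between the other two, a 1.1-fold lower number from compound 2 to compound 3 (0.05 log units; within the scatter) is also within the scatter, so the three compounds are not told apart by these numbers.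

Compound 4, `Cc1ccc(-c2nnc(SCCn3c([N+](=O)[O-])cnc3C)o2)c(O)c1`, has not yet been measured in this assay. It differs from compound 1 as follows: 2-hydroxy-4-methylphenyl in place of 4-methoxyphenyl on an aromatic carbon.

Within the data shown here, none of the measured steps reproduces this change. What the measured steps do show is that, on the ring that is altered here, substituting ethoxy or dimethylamino for methoxy gave steps within the scatter. A rearrangement of the same atoms within that ring is expected to behave similarly in this assay, with no step beyond the scatter in either direction. The step from compound 1 to compound 4 is thus estimated as a 1.1-fold higher number from compound 1 to compound 4 (0.05 log units; within the scatter). Compound 4 is therefore expected to give about 12000 nM, with a range from 5000 nM to 30000 nM.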

Compound 4, half-maximal inhibitory concentration: 23500 nM
The estimate for compound 4 lay 2.0-fold (0.29 log units) below the measured number; the range from low to high includes it.
By their numbers in this assay, from the lowest: compounds 1, 3, 2 and 4 (each within the scatter of the next, the first and the last beyond it).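

In this assay, among these compounds, the change to 2-hydroxy-4-methylphenyl from 4-methoxyphenyl gives a 2.2-fold higher number from compound 1 to compound 4 (0.35 log units; beyond the scatter) as the only step in this small set that lies beyond the scatter, and it is a modest one. This shows that the place on the five-membered aromatic ring with 2 nitrogen and 1 oxygen can respond to a change of the aromatic substituent, even when the same atoms are only joined differently, whereas the exchanges among methoxy, ethoxy and dimethylamino had not told the compounds apart. The change also brings in a hydrogen-bond donor that 4-methoxyphenyl lacks, but no available evidence accounts for the step.

The compounds shown leave open whether the hydroxy group or the methyl group carries the step: none of them changes only one of the two. Going by these compounds, it also remains open how an amine or a carboxylic acid in place of the hydroxy group would read in this assay on this otherwise unchanged core.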